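Swapping a Basic Amine for a Tertiary Alcohol

The source may report more compounds than this note shows. Statements on the series, on what has been measured and on what is new or still open speak of the compounds shown alone.

Compound 1, `CCCCNc1nc(N)nc(C)c1CCCn1c(C)nc2ccccc21`, gives 366 nM.
Compound 2, `CCCCNc1nc(N)nc(C)c1CCCN(CC)CC`, gives 254 nM.
Compound 3, `CCCCNc1nc(N)nc(C)c1CCCCCc1ccccc1`, gives 830 nM.

All three were tested in an assay on HEK293 cells for agonist activity at Toll-like receptor 8 (Homo sapiens), read by spectrophotometry; a lower number here means that less compound is needed, a higher number that more compound is needed for the effect. Compound 2 has the lowest number of the three, though compound 1 sits within the scatter of it, so the two cannot be told apart; compound 3 lies clearly higher.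

Compound 4, `CCCCNc1nc(N)nc(C)c1CCC(C)(C)O`, has not yet been measured. Compared with compound 2 the change is 1-hydroxy-1-methylethyl in place of (diethylamino)methyl on a saturated chain carbon, two bonds along the chain from an aromatic carbon. Within the data shown here, the only measured step that speaks to this is the one that also removes the diethylamino group: a 3.3-fold higher number from compound 2 to compound 3 (0.51 log units; beyond the scatter). That step exchanged the amine for an aromatic group at a slightly different place on the chain, so it is only a rough guide, and nothing measured here shows what a hydroxyl group does at this position.

On that basis a modest rise in the number is expected for compound 4, in the direction of the step from compound 2 to compound 3, giving a 2.4-fold higher number from compound 2 to compound 4 (0.37 log units; beyond the scatter). The estimate for compound 4 in this assay is 600 nM, with a range from 200 nM to 2000 nM.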

Compound 4, half-maximal effective concentration: 3140 nM
Beside the measured number, compound 4's estimate is 5.2-fold (0.72 log units) below it; measured number outside the range, above it.
By their numbers in this assay, from the lowest: compounds 2 and 1 (each within the scatter of the next); then compound 3; then compound 4.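

In this assay, putting 1-hydroxy-1-methylethyl in place of (diethylamino)methyl on a saturated chain carbon, two bonds along the chain from an aromatic carbon, brings a 12-fold higher number from compound 2 to compound 4 (1.09 log units; beyond the scatter) and so counts as a large step. The earlier step that also removed the diethylamino group, a 3.3-fold higher number from compound 2 to compound 3 (0.51 log units; beyond the scatter) at a slightly different place on the chain, was only modest, so losing that amine does not come with one fixed cost, and the hydroxyl-bearing group proves a poor stand-in for it at this position. Nothing available here explains why this step is so large.

The change does several things at once: the nitrogen leaves, a hydrogen-bond donor enters, and the new group has fewer heavy atoms, so the compounds shown cannot say which of these drives the rise. A primary amine or a dimethylamino group at this place would test whether a smaller amine holds the number down, while a methyl ether in place of the hydroxyl would test whether the hydrogen-bond donor itself matters.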